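The source may report more compounds than this note shows. Statements on the series, on what has been measured and on what is new or still open speak of the compounds shown alone.

Values so far, all from a functional assay on SGC-7901 cells (Homo sapiens) for antiproliferative activity, read by MTT assay, with a stated time of 48 h (a lower number here means a stronger inhibitor, a higher number a weaker inhibitor), as the read-out:
- compound 1 `CC(=O)N1N=C(c2ccccc2)CC1c1ccc2c(c1)OCCO2` gives 50200 nM
- compound 2 `CC(=O)N1N=C(c2ccc(F)cc2)CC1c1ccc2c(c1)OCCO2` gives 68400 nM

Within the data shown here, compound 2 stands within the scatter of compound 1, its only neighbour on the numbers, so the two values cannot be ranked. The measured step between them reads (a 1.4-fold higher number from compound 1 to compound 2 (0.13 log units; within the scatter)).

Compound 3 `CC(=O)N1N=C(c2ccc(Cl)cc2)CC1c1ccc2c(c1)OCCO2` is not yet measured. Its change from compound 2 is chloro in place of fluoro on an aromatic carbon, para to a large group (chloro in place of fluoro on an aromatic carbon).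

Among the measured compounds shown here, only one measured step bears on this change: the fluoro for hydrogen exchange at the same place (a 1.4-fold higher number from compound 1 to compound 2 (0.13 log units; within the scatter)). For the measured compounds named here, that step stayed within the scatter, and no chloro compound has a measured value yet, so this exchange has no direct precedent. With so little to go on, no step beyond the scatter is expected in this assay in either direction. The estimated step is small (a 1.2-fold lower number from compound 2 to compound 3 (0.07 log units; within the scatter)). The estimated value for compound 3 is 58000 nM (expected range 25000 nM to 130000 nM).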

Compound 3, half-maximal inhibitory concentration: 59500 nM
For compound 3 the middle estimate is 1.0-fold (0.01 log units) below the measured one, within the range that was stated.
By their numbers in this assay, from the lowest: compounds 1, 3 and 2 (each within the scatter of the next).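

In this assay, the 4-fluorophenyl to 4-chlorophenyl exchange gives a 1.1-fold lower number from compound 2 to compound 3 (0.06 log units; within the scatter) and so leaves the number within the scatter, and the chloro in place of hydrogen comparison gives a 1.2-fold higher number from compound 1 to compound 3 (0.07 log units; within the scatter) with the same reading. The earlier pair tested only fluoro against hydrogen, whereas this place now carries three different substituents, and the three compounds cannot be ranked because each value lies within the scatter of the other two. The exchange of one halogen for another at this aromatic carbon, and the entry of chloro in place of hydrogen, thus add a second and a third comparison that show no separation in this assay, and no measurement is at hand that would explain this reading.

Still open, on these data alone, is whether a group other than a halogen at this place, such as an amine, a methoxy group or a carboxylic acid, would give a step beyond the scatter from compound 1. Also open is whether changes elsewhere on the shared core, such as a longer chain in place of the acetyl group, would separate any compound from the three shown here.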